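A few compounds are considered here, and "the series" means these few. Any claim that something is new, unique, unknown or untested is made for them only; others in the source may bear on it.

Measured compounds in a functional assay on HeLa cells (Homo sapiens) for inhibition, read by MTT assay; a lower number here means a stronger inhibitor, a higher number a weaker inhibitor:
compound 1 `CCCCCCCCCCn1cc(/C=C/C(=O)c2ccc(NC(=O)CN3CCN(c4ccccc4)CC3)cc2)nn1`, 59100 nM
compound 2 `O=C(CN1CCN(c2ccccc2F)CC1)Nc1ccc(C(=O)/C=C/c2cn(Cc3ccc(Br)cc3)nn2)cc1`, 9120 nM
compound 3 `O=C(CN1CCN(c2ccc([N+](=O)[O-])cc2)CC1)Nc1ccc(C(=O)/C=C/c2cn(Cc3ccc(Br)cc3)nn2)cc1`, 26600 nM

Among these three numbers compound 3 stands second highest in this assay. Its nearest neighbour is compound 1, which gives 59100 nM; compound 2 sits furthest from it with 9120 nM. Among the compounds with values here, the one single-point step in this set is the change a 2.9-fold higher number from compound 2 to compound 3 (0.46 log units; beyond the scatter), which concerns the aryl group on the amine nitrogen in the ring and not the part altered next.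

Compound 4 `CCCCCCCCCCn1cc(/C=C/C(=O)c2ccc(NC(=O)CN3CCN(c4ccc([N+](=O)[O-])cc4)CC3)cc2)nn1` differs from compound 3 by nonyl in place of 4-bromophenyl on a saturated chain carbon bound to an aromatic nitrogen. Within the data shown here, no measured pair isolates this change: compound 1 carries decyl on the aromatic nitrogen but plain phenyl on the ring amine, so its difference from compound 4 lies elsewhere, and its difference from compound 2 and compound 3 lies in two places. Among the measured compounds shown here, what the numbers show is that the only decyl-bearing compound, compound 1, gives the highest value, and the two 4-bromobenzyl compounds sit below it. On that thin basis a rise beyond the scatter is expected in this assay, with the estimate for compound 4 set near the value of compound 1; the expected step of a 2.3-fold higher number from compound 3 to compound 4 (0.35 log units; beyond the scatter) is modest and upward. Compound 4 is thus estimated at 60000 nM, with a range from 20000 nM to 150000 nM.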

Compound 4, half-maximal inhibitory concentration: 65900 nM
Compound 4: middle estimate off by 1.1-fold (0.04 log units), on the low side, and the stated range covers the measured number.
By their numbers in this assay, from the lowest: compound 2; then compound 3; then compounds 1 and 4 (each within the scatter of the next).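

In this assay, the exchange of 4-bromobenzyl for decyl on the aromatic nitrogen now stands alone in one pair, with the 4-nitrophenyl group held constant on the ring amine: the step is a 2.5-fold higher number from compound 3 to compound 4 (0.39 log units; beyond the scatter) and gives direct support for the lower number with 4-bromobenzyl at this position in this one pair. With decyl held constant, nitro in place of hydrogen on an aromatic carbon gives a 1.1-fold higher number from compound 1 to compound 4 (0.05 log units; within the scatter) and so does not separate these two decyl compounds in this assay. No measured property accompanies these numbers, and the data give no explanation for either step.

The compounds shown leave open whether the step from 4-bromobenzyl to decyl carries over to other groups on the ring amine, such as the 2-fluorophenyl group of compound 2. They also leave open where an unsubstituted benzyl group, a shorter chain such as hexyl, or a chain ending in a carboxylic acid would fall on the aromatic nitrogen relative to 4-bromobenzyl and decyl.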